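Pyridinyl arm restored on the exocyclic carbon: compound 2 to 4

A few compounds are considered here, and "the series" means these few. Any claim that something is new, unique, unknown or untested is made for them only; others in the source may bear on it.

Compound 2 `O=C1N=C(N2CCC[C@H]2C(=O)Nc2ccc3ncnc(Nc4cccc(Cl)c4)c3c2)S/C1=C/c1ccccc1[N+](=O)[O-]` gives the highest number of the three in a functional assay on HepG2 cells (Homo sapiens) for antiproliferative activity, read by MTT assay (a higher number here means a weaker inhibitor, a lower number a stronger inhibitor), at 32500 nM; compound 3 `O=C1N=C(N2CCC[C@H]2C(=O)Nc2ccc3ncnc(Nc4cccc(Cl)c4)c3c2)S/C1=C/c1cccc(Br)c1` gives 21300 nM, a gap within the scatter, while compound 1 `O=C1N=C(N2CCC[C@H]2C(=O)Nc2ccc3ncnc(Nc4cccc(Cl)c4)c3c2)S/C1=C/c1cccc(Br)n1` gives 2700 nM. Compound 4 `Cc1cccc(/C=C2/SC(N3CCC[C@H]3C(=O)Nc3ccc4ncnc(Nc5cccc(Cl)c5)c4c3)=NC2=O)n1` differs from compound 2 as follows: 6-methylpyridin-2-yl in place of 2-nitrophenyl on a double-bonded chain carbon bound to a double-bonded ring carbon. Within the data shown here, two measured steps bear on this change, a 12-fold higher number from compound 1 to compound 2 (1.08 log units; beyond the scatter) and a 7.9-fold higher number from compound 1 to compound 3 (0.90 log units; beyond the scatter), both setting the 6-bromopyridin-2-yl compound 1 well apart from the phenyl analogs, whereas a 1.5-fold lower number from compound 2 to compound 3 (0.18 log units; within the scatter) lies within the scatter. Since 6-methylpyridin-2-yl brings back the pyridinyl arm of compound 1, a large fall in the number from compound 2 is expected, about an 8.1-fold lower number from compound 2 to compound 4 (0.91 log units; beyond the scatter). Compound 4 is therefore estimated at 4000 nM in this assay, within 1500 nM to 12000 nM.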

Compound 4, half-maximal inhibitory concentration: 4500 nM
Compound 4: middle estimate off by 1.1-fold (0.05 log units), on the low side; measured number inside the range.
By their numbers in this assay, from the lowest: compounds 1 and 4 (each within the scatter of the next); then compounds 3 and 2 (each within the scatter of the next).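

In this assay, 6-methylpyridin-2-yl on the double-bonded chain carbon gives a 7.2-fold lower number from compound 2 to compound 4 (0.86 log units; beyond the scatter) and also a 4.7-fold lower number from compound 3 to compound 4 (0.68 log units; beyond the scatter), so the low number of compound 1 is not tied to its bromo group. Methyl in place of bromo on the aromatic carbon gives only a 1.7-fold higher number from compound 1 to compound 4 (0.22 log units; within the scatter) and so leaves the pyridinyl compounds together. No evidence on the result accounts for this. Still open, going by these compounds, is how far the ring nitrogen alone sets the number: an unsubstituted pyridin-2-yl or a 3-methylphenyl arm would test this, and a 6-aminopyridin-2-yl arm would extend the substituent range.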